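Swapping Chloro for Nitro on a Sulfone Analogue

The compounds below may be only part of what the source reports. "The series", "measured", "known", "first", "only" and "open" are said of these compounds alone.

Of the compounds shown here, three have been tested in a functional assay on DU-145 cells (Homo sapiens) for inhibition, read by trypan blue exclusion, with a stated time of 96 h; a lower number here means a stronger inhibitor of growth, a higher number a weaker inhibitor of growth. Compound 2 `COc1ccccc1/C=C(/SCc1ccc(Cl)cc1)C(=O)c1ccc(Cl)cc1` gives 1000 nM, compound 1 `COc1ccccc1/C=C(/SCc1ccc(Cl)cc1)C(=O)c1ccc([N+](=O)[O-])cc1` gives 10000 nM, and compound 3 `COc1ccccc1/C=C(\C(=O)c1ccc(Cl)cc1)S(=O)(=O)Cc1ccc(Cl)cc1` gives 25000 nM. Compound 1 and compound 2 differ in one place: nitro in place of chloro on an aromatic carbon. That change gave a 10-fold higher number from compound 2 to compound 1 (1.00 log units; beyond the scatter). The difference between the core of compound 3 and the core of compound 2 is not broken down here. Compound 4 `COc1ccccc1/C=C(\C(=O)c1ccc([N+](=O)[O-])cc1)S(=O)(=O)Cc1ccc(Cl)cc1` carries the same change on the core of compound 3: nitro in place of chloro on an aromatic carbon. The place of the change reads the same in both pairs, so it is taken as the same change. Compound 4 is expected to show a step of about an 8.0-fold higher number from compound 3 to compound 4 (0.90 log units; beyond the scatter), beside the earlier step, because compound 3 stands at 25000 nM and the earlier pair gave a 10-fold higher number from compound 2 to compound 1 (1.00 log units; beyond the scatter). The estimate for compound 4 is 200000 nM, expected to fall between 50000 nM and 600000 nM.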

Compound 4, concentration for 50% growth inhibition: 10000 nM
Compound 4: the middle estimate sits 20-fold (1.30 log units) above what was measured; measured number outside the range, below it.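

Nitro in place of chloro gave a 2.5-fold lower number from compound 3 to compound 4 (0.40 log units; beyond the scatter), the opposite direction to the earlier step, and the two steps clearly disagree: the same change on two cores in this assay, a 10-fold higher number (1.00 log units; beyond the scatter) from compound 2 to compound 1 and a 2.5-fold lower number (0.40 log units; beyond the scatter) from compound 3 to compound 4, 25-fold (1.40 log units) apart, beyond the scatter of two such steps

So in this series, the result of this change on one core did not predict its result on the other, in direction or in size. The two pairs do not show why the cores differ, nor which result would be more typical on a further core.

The compounds shown leave open whether another group in the same place, such as an amine or a carboxylic acid, would also give opposite steps on these two cores.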